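The compounds below may be only part of what the source reports. "The series", "measured", "known", "first", "only" and "open" are said of these compounds alone.

Among the measured compounds shown here, compound 2 `O=C(Nc1ccc(Cl)c(-c2nnc3c(Cl)cccn23)c1)c1cccc(Cl)c1` carries a 3-chlorophenyl on the carbonyl carbon of its amide and in a functional assay on MDA-MB-468 cells (Homo sapiens) for antiproliferative activity, read by MTT assay, with a stated time of 72 h (a higher number here means a weaker inhibitor, a lower number a stronger inhibitor), compound 2 gives 54800 nM, the only full number available. Its companion, compound 1 `Cc1nc(C(=O)Nc2ccc(Cl)c(-c3nnc4c(Cl)cccn34)c2)cs1`, differs only in the group on that carbonyl carbon. In this assay compound 1 reaches no number at all, only the limit > 100000 nM (the limit of > 100000 nM in this assay, at which 1 of the 2 values shown sits). For the measured compounds named here, the one comparison on record therefore runs from a thiazole to a chlorophenyl and gives an at least 1.8-fold lower number from compound 1 to compound 2 (0.26 log units; that floor lies within the scatter), a floor that sits within the scatter.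

Compound 3 `CS(=O)(=O)c1ccc(C(=O)Nc2ccc(Cl)c(-c3nnc4c(Cl)cccn34)c2)cc1` takes the same step again but on the other side: 4-(methylsulfonyl)phenyl in place of 3-chlorophenyl on a carbonyl carbon. Going by the values given here, no measured pair tests a methylsulfonylphenyl here, and the only step that touches this position is the one from compound 1 to compound 2, which was small. On that basis the expected change in this assay is none beyond the scatter, so the step is estimated as a 1.5-fold higher number from compound 2 to compound 3 (0.16 log units; within the scatter). For compound 3 the expected value in this assay is therefore 80000 nM, within a range of 25000 nM to 250000 nM, with a real chance that only a limit is returned.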

Compound 3, half-maximal inhibitory concentration: > 100000 nM
Compound 3: no number, only a limit; the forecaster's own chance of this, stated with the estimate: 40%; middle value at least 1.2-fold (0.09 log units) away from the limit.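

Compound 3, like compound 1, returns only a limit, so two of the three groups on this carbonyl carbon now leave this assay without a full number: the limit of > 100000 nM in this assay, at which 2 of the 3 values shown sit.

The change from 3-chlorophenyl to 4-(methylsulfonyl)phenyl gives an at least 1.8-fold higher number from compound 2 to compound 3 (0.26 log units; that floor lies within the scatter), which is a floor and not a measured size, so this second change at the position also fails to stand clear of the scatter. Among the compounds shown here, the step between the two compounds that sit at the limit cannot be read, which leaves compound 2 as the only point with a full number and no pair of compounds that shows how large a change at this position can be.

The compounds shown leave open whether any group on this carbonyl carbon can bring the number in this assay far below that of compound 2, or whether all of them stay close to the limit. From the compounds shown here alone, an amine or a carboxylic acid carried on the phenyl ring, or a longer alkyl chain in place of that ring, remains untested in this set and might return a full number that gives the position a readable step.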